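Adding a Methyl to the Benzamide of Compound 2

The source may report more compounds than this note shows. Statements on the series, on what has been measured and on what is new or still open speak of the compounds shown alone.

Compound 1 `CCCCCCCCCCC(C)(C)NC(=O)c1c(OC)cc(OC)cc1OC`; in an assay on microsomes from liver for inhibition of sterol O-acyltransferase 1 (Rattus norvegicus) (a higher number here means a weaker inhibitor, a lower number a stronger inhibitor), compound 1 reports only a limit, > 10000 nM
Compound 2 `CCCCCCCCCCCCn1nnc(C(NC(=O)c2ccccc2)c2ccccc2)n1`; in this assay compound 2 gives 350 nM

Among the measured compounds shown here, compound 2 stands alone as the only real number measured here, since the other value recorded is a limit of the assay rather than a number. Compound 3 `CCCCCCCCCCCCn1nnc(C(NC(=O)c2ccc(C)cc2)c2ccccc2)n1` differs from compound 2 in a single place: methyl in place of hydrogen on an aromatic carbon. For the measured compounds named here, no measured pair shows a step of this kind, so the expected step is one that stays within the usual scatter, a 1.2-fold lower number from compound 2 to compound 3 (0.07 log units; within the scatter). For compound 3 the estimated value in this assay is 300 nM, with a likely range from 120 nM to 800 nM.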

Compound 3, half-maximal inhibitory concentration: 510 nM
Estimate against measurement, compound 3: 1.7-fold (0.23 log units) below; low and high end bracket the measured number.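

In this assay, among the compounds shown here, the change from phenyl to 4-methylphenyl gives a 1.5-fold higher number from compound 2 to compound 3 (0.16 log units; within the scatter) as the only step here between compounds that differ in one place. For the compounds shown here, this position therefore takes a methyl without a real shift in the number, which the earlier compounds could not show. Nothing measured here bears on why the number stays put.

Still open, as far as these compounds go, is whether an amine, a carboxylic acid or a longer chain at this same place would move the number beyond the usual scatter. From the compounds shown here alone, whether a methyl elsewhere on this ring would behave the same also remains unknown.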